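Swapping an amino group for benzylsulfanyl on a nucleotide core

A few compounds are considered here, and "the series" means these few. Any claim that something is new, unique, unknown or untested is made for them only; others in the source may bear on it.

Compound 1 `Nc1nc(=O)ccn1[C@@H]1O[C@H](COP(=O)(O)O)[C@@H](O)[C@H]1O` was tested in an in vitro functional assay on 1321-N1 cells for agonist activity at P2Y purinoceptor 2 (Homo sapiens), read by scintillation proximity assay and inositol phosphate accumulation; a lower number here means that less compound is needed, a higher number that more compound is needed for the effect. For compound 1 the assay reports only a limit, > 100000 nM. Going by these compounds, compound 1 therefore sits at the limit of > 100000 nM in this assay, at which 1 of the 2 values shown sits, so its true value is unknown. A second measured compound, compound 2 `O=c1ccn([C@@H]2O[C@H](COP(=O)(O)OP(=O)(O)O)[C@@H](O)[C@H]2O)c(SCCc2ccccc2)n1`, gives 544 nM in this assay. The unmeasured compound 3 `O=c1ccn([C@@H]2O[C@H](COP(=O)(O)O)[C@@H](O)[C@H]2O)c(SCc2ccccc2)n1` differs from compound 1 in one place: benzylsulfanyl in place of amino on an aromatic carbon. For compound 3 the estimated value in this assay is 30000 nM, with a range from 3000 nM to 100000 nM. The step of an at least 3.3-fold lower number from compound 1 to compound 3 (0.52 log units; beyond the scatter) is expected to lead toward a lower number, though a limit may again be reported.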

Compound 3, half-maximal effective concentration: >= 100000 nM
Compound 3: only a limit was reported; the forecaster's own chance of this, stated with the estimate: 40%; at least 3.3-fold (0.52 log units) between middle value and limit.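

Compound 1 and compound 3 each give only a limit, so no step can be read between them. The compounds shown leave open whether benzylsulfanyl in place of amino changes the number at all.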